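The compounds below may be only part of what the source reports. "The series", "measured", "known", "first", "only" and "open" are said of these compounds alone.

Compound 1 `CCC(CC)n1c(=O)[nH]c2ncc(C(F)(F)F)nc21`, < 0.2 in an ADME assay on microsomes from liver (Homo sapiens), read by LC-MS, with a stated time of 90 min; a lower number here means that the liver removes a smaller share, a higher number that the liver removes a larger share of the compound in one pass.
Compound 2 `CC#Cc1cnc2[nH]c(=O)n(C(CC)CC)c2n1`, "not determined" (no result reported) in this assay.
Compound 3 `CCC(CC)n1c(=O)[nH]c2ncc(C#N)nc21`, not yet measured in this assay.

In this assay compound 1 gives < 0.2, which is a limit of the assay and not a number. For the measured compounds named here, compound 2 has no number of its own here, and the one further value shown is the limit of < 0.2 in this assay, at which 1 of the 2 values shown sits. So compound 2 stands without a measured place, and nothing ties its structure to a figure. Compound 3 arises from compound 2 through (cyano in place of prop-1-yn-1-yl on an aromatic carbon). Going by the values given here, no measured pair shows the effect of this change in this assay, so there is no step to lean on; the expectation is a step of no size beyond the scatter, in no fixed direction. The only anchor is the limit that compound 1 reaches. Compound 3 is therefore expected to give about 0.15 in this assay, between 0.05 and 0.35.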

Compound 3, hepatic extraction ratio: < 0.2
Compound 3 was reported as a limit; the forecaster's own chance of this, stated with the estimate: 50%; the middle value lies beyond the limit too.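

Compound 1 and compound 3 both give a limit of the assay and not a number, so no step between them can be read: the limit of < 0.2 in this assay, at which 2 of the 3 values shown sit.

The compounds shown leave open whether cyano in place of trifluoromethyl changes the result in this assay at all, and by how much.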